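A few compounds are considered here, and "the series" means these few. Any claim that something is new, unique, unknown or untested is made for them only; others in the source may bear on it.

Of the compounds shown here, three here have been tested in a functional assay on UACC-257 cells (Homo sapiens) for inhibition, read by sulforhodamine B assay, with a stated time of 48 h; a higher number here means a weaker inhibitor of growth, a lower number a stronger inhibitor of growth. Compound 1 `O=C(Nc1cccc(-n2cc(-c3ccncc3)c(-c3ccc(Cl)c(O)c3)n2)c1)Nc1ccc(Cl)c(Cl)c1` gives 3160 nM, and compound 3 `O=C(Nc1cccc(-n2cc(-c3ccncc3)c(-c3ccc(Cl)c(O)c3)n2)c1)Nc1cc(C(F)(F)F)cc(C(F)(F)F)c1` gives 2550 nM; these two values lie within the usual scatter of each other. Compound 2 `COc1cc(-c2nn(-c3cccc(NC(=O)c4cccc(C(F)(F)F)c4)c3)cc2-c2ccncc2)ccc1Cl` stands apart: in this assay compound 2 gives > 50000 nM, which is a limit of the assay rather than a number, so compound 2 sits at the limit of > 50000 nM in this assay, at which 1 of the 3 values shown sits.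

Compound 4 `COc1cc(-c2nn(-c3cccc(NC(=O)Nc4ccc(Cl)c(C(F)(F)F)c4)c3)cc2-c2ccncc2)ccc1Cl` has not yet been measured. It is built from compound 2 by one change on a carbonyl carbon whose other neighbour is an amide-type nitrogen: (4-chloro-3-(trifluoromethyl)phenyl)amino in place of 3-(trifluoromethyl)phenyl on a carbonyl carbon. The group that enters brings an amino group onto the carbonyl, so that compound 4 carries the same kind of linkage that compound 1 and compound 3 carry, while keeping the rest of compound 2.

For the measured compounds named here, no step between measured compounds is available to calibrate this change. Since compound 1 and compound 3, which carry such a linkage, each give a number in this assay while compound 2 gives only a limit, compound 4 is expected to show stronger growth inhibition than compound 2, a step estimated as an at least 5.0-fold lower number from compound 2 to compound 4 (0.69 log units; beyond the scatter). For compound 4 the expected value in this assay is 10000 nM, with a likely range from 3000 nM to 50000 nM.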

Compound 4, concentration for total growth inhibition: 6030 nM
Compound 4: middle estimate off by 1.7-fold (0.22 log units), on the high side; the range from low to high includes it.
By their numbers in this assay, from the lowest: compounds 3, 1 and 4 (each within the scatter of the next, the first and the last beyond it). At a limit, above all of these: compound 2.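

In this assay, for the compounds shown here, the change on the carbonyl carbon gives the first pair of compounds that differ in one place, and it takes the read-out from a limit to a real number: an at least 8.2-fold lower number from compound 2 to compound 4 (0.91 log units; beyond the scatter). It also shows that a compound keeping the methoxy group of compound 2 can inhibit growth measurably here, which compound 1 and compound 3, both carrying a hydroxy group instead, could not show. The true size of the step stays unknown, and only its lower bound can be read, since compound 2 is given as a limit and not as a number: the limit of > 50000 nM in this assay, at which 1 of the 4 values shown sits.

From the compounds shown here alone, the entering group brings an amino group and a chlorine at once, so it remains open whether the amino group alone or the chlorine alone would move compound 2 off its limit, and what a methylene or a methylamino on the carbonyl would do in place of that amino group. No pair shown differs only in hydroxy against methoxy, so the part that group plays in this assay cannot be read.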